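Benzyl at the Aminopyrimidine Nitrogen: Expected Rat Exposure

The compounds below may be only part of what the source reports. "The series", "measured", "known", "first", "only" and "open" are said of these compounds alone.

Compound 1 `CNc1nc(C)c(-c2nc3ccccc3s2)c(N[C@@H]2C[C@H](CO)[C@@H](O)[C@H]2O)n1`: 1080 ng.h/mL
Compound 2 `Cc1nc(NC(C)(C)C)nc(N[C@@H]2C[C@H](CO)[C@@H](O)[C@H]2O)c1-c1nc2ccccc2s1`: 2220 ng.h/mL
Compound 3 `Cc1nc(NCCOC(C)C)nc(N[C@@H]2C[C@H](CO)[C@@H](O)[C@H]2O)c1-c1nc2ccccc2s1`: 426 ng.h/mL

In an ADME assay on the whole organism (plasma) for pharmacokinetics, with Rattus norvegicus as the target, with a stated time of 6 h, at a dose of 10 mg/kg by the oral route (on this read-out lower numbers stand for lower exposure and higher numbers for higher exposure at the dose given), compound 1 stands second highest of the three, with compound 2 above it by a 2.1-fold higher number from compound 1 to compound 2 (0.31 log units; beyond the scatter) and compound 3 below it by a 2.5-fold lower number from compound 1 to compound 3 (0.40 log units; beyond the scatter). Compound 4 `Cc1nc(NCc2ccccc2)nc(N[C@@H]2C[C@H](CO)[C@@H](O)[C@H]2O)c1-c1nc2ccccc2s1` differs from compound 1 by phenyl in place of hydrogen on a saturated chain carbon bound to a nitrogen on an aromatic ring. Both measured steps change the same nitrogen substituent and point in opposite directions, so a larger group here has gone either way by modest amounts. Among the measured compounds shown here, no measured compound carries a phenyl on this chain. A modest step, if any, is therefore expected for compound 4, estimated as a 1.3-fold lower number from compound 1 to compound 4 (0.10 log units; within the scatter), with the direction uncertain. Compound 4 is expected to give about 850 ng.h/mL, within a range from 300 ng.h/mL to 2400 ng.h/mL.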

Compound 4, area under the concentration-time curve: 1050 ng.h/mL
Compound 4: the middle estimate sits 1.2-fold (0.09 log units) below what was measured, and the stated range covers the measured number.
By their numbers in this assay, from the lowest: compound 3; then compounds 4 and 1 (each within the scatter of the next); then compound 2.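

In this assay, phenyl on the saturated chain carbon bound to the nitrogen leaves the number within the scatter (a 1.0-fold lower number from compound 1 to compound 4 (0.01 log units; within the scatter)), so adding this ring to the methylamino group gives no readable step. Benzyl nonetheless stands apart from the two other nitrogen substituents, both on the 2-isopropoxyethyl side (a 2.5-fold higher number from compound 3 to compound 4 (0.39 log units; beyond the scatter)) and on the tert-butyl side (a 2.1-fold lower number from compound 2 to compound 4 (0.33 log units; beyond the scatter)), so the group's identity at this nitrogen still matters. Nothing available here accounts for these differences.

The compounds shown leave open whether a longer chain such as phenylethyl, or a benzyl carrying a carboxylic acid, would keep this exposure.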